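This account rests on a few compounds, and the source may have more. Where it says the series, first, only, none or still open, it means among the compounds named here.

Measured so far in a physicochemical assay for lipophilicity, in phosphate buffer, measured as octanol-water partition; a lower number here means a more polar compound, a higher number a more lipophilic compound:
- compound 1 `CCCc1nc2ccccc2c(=O)n1/N=C/c1ccc(Oc2ccc(Cl)cc2)cc1`: 5.78
- compound 2 `Cc1ccc(Oc2ccc(/C=N/n3c(-c4ccccc4)nc4ccccc4c3=O)cc2)cc1`: 6.29
- compound 3 `CCCc1nc2ccccc2c(=O)n1/N=C1/C(=O)Nc2ccccc21`: 3.23

Among these three numbers compound 1 holds the second highest place. Compound 2 gives a higher number, and the gap lies beyond the usual scatter of this assay; compound 3 gives a far lower number, again beyond the scatter. The next compound, compound 4 `CCCc1nc2ccccc2c(=O)n1/N=C/c1ccc(Oc2ccc([N+](=O)[O-])cc2)cc1`, has not yet been measured. It differs from compound 1 in one place: nitro in place of chloro on an aromatic carbon. For the measured compounds named here, no measured pair in this set shows this exact change, so the size of the step must be estimated from the structures alone. The step from compound 1 to compound 4 is expected to lower the partition coefficient beyond the scatter, by about a number 0.98 log units lower from compound 1 to compound 4 (beyond the scatter). Compound 4 is therefore expected to give 4.8, in a range from 4.3 to 5.3.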

Compound 4, partition coefficient: 5.18
Beside the measured number, compound 4's estimate is 0.38 log units below it; the measured number falls inside the stated range.
By their numbers in this assay, from the lowest: compound 3; then compound 4; then compound 1; then compound 2.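

Nitro in place of chloro, on an aromatic carbon para to a large group, gives the first one-place comparison in this set: in this assay the change reads a number 0.60 log units lower from compound 1 to compound 4 (beyond the scatter) with the rest of the molecule held the same. So this position can shift the number beyond the scatter, although a single pair sets no trend. Nothing shown here explains the size of this step. Other groups at this place, such as an amine or a carboxylic acid, remain open. So does whether the same change gives a similar step on the core of compound 2.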